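This account rests on a few compounds, and the source may have more. Where it says the series, first, only, none or still open, it means among the compounds named here.

Compound 1 `Cc1nnc(-c2cccc(-c3ccc(C(=O)N(Cc4cccc(OCCCCCC(=O)O)c4)C(C)C)cc3)c2)o1`: in an ADME assay on BJ cells (Homo sapiens) for cytotoxicity, read by CellTiter-Glo and resazurin assay, with a stated time of 72 h (a higher number here means that more compound is needed for the effect, a lower number that less compound is needed), compound 1 gives > 26000 nM, which is a limit of the assay.
Compound 2 `CCOC(=O)CCCCCOc1cccc(CN(C(=O)c2ccc(-c3cccc(N(C)C)c3)cc2)C(C)C)c1`: in this assay compound 2 gives > 26000 nM, also a limit of the assay.

Compound 2 thus stands at the limit of > 26000 nM in this assay, at which 2 of the 2 values shown sit. Among the compounds with values here, both values shown are limits, so no compound in this set has a measured number, and nothing sets the two apart. Compound 3 `CCOC(=O)CCCCCOc1cccc(CN(C(=O)c2ccc(-c3ccc(C(C)=O)s3)cc2)C(C)C)c1` differs from compound 2 in one place: 5-acetylthiophen-2-yl in place of 3-(dimethylamino)phenyl on an aromatic carbon. Within the data shown here, no step between measured compounds is available, so the expectation for compound 3 rests on the two limits alone. The change from compound 2 to compound 3 is expected to bring no step beyond the scatter in this assay, a step that the limit leaves unreadable from compound 2 to compound 3, and compound 3 is most likely expected to come back as a limit as well. Compound 3 is estimated at 30000 nM in this assay, within a range from 15000 nM to 80000 nM.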

Compound 3, half-maximal effective concentration: > 26000 nM
Compound 3 ended at the assay's limit; the forecaster's own chance of this, stated with the estimate: 80%; the middle value is on the limit's open side.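

In this assay, within the data shown here, compound 2 and compound 3 both sit at a limit of the assay, so no step between them can be read: the limit of > 26000 nM in this assay, at which 3 of the 3 values shown sit.

The compounds shown leave open how much of any of them would be needed for the effect, and whether 5-acetylthiophen-2-yl in place of 3-(dimethylamino)phenyl changes that at all.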